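Turning the phenyl substituent: from 2-methyl to 4-trifluoromethyl

The compounds below may be only part of what the source reports. "The series", "measured", "known", "first", "only" and "open" are said of these compounds alone.

Compound 1 `O=C(Nc1cc(-c2ccccc2)nn1-c1ccccc1)c1cccc(Cl)c1` and compound 2 `Cc1ccccc1C(=O)Nc1cc(-c2ccccc2)nn1-c1ccccc1` share a core and differ only in the ring on the carbonyl carbon. In an assay on CHO cells with metabotropic glutamate receptor 5 (Homo sapiens) as the target (on this read-out higher numbers stand for an effect only at larger amounts of compound and lower numbers for an effect already at smaller amounts), compound 1 gives 40 nM. For compound 2 this assay reports only a limit, > 10000 nM, so its true number is not known (the limit of > 10000 nM in this assay, at which 1 of the 2 values shown sits). Going by the values given here, the step of an at least 250-fold higher number from compound 1 to compound 2 (2.39 log units; beyond the scatter) is therefore the only measured change here, and it is large. Compound 3 `O=C(Nc1cc(-c2ccccc2)nn1-c1ccccc1)c1ccc(C(F)(F)F)cc1` is not yet measured; it carries 4-(trifluoromethyl)phenyl in place of 2-methylphenyl on a carbonyl carbon. Among the compounds with values here, no measured pair shows this exact change, but the single measured step points one way: leaving the 2-methylphenyl of compound 2 for another substituted ring, as in compound 1, lowered the number strongly. Compound 3 is therefore expected to sit well below the limit of compound 2, with a step of an at least 20-fold lower number from compound 2 to compound 3 (1.30 log units; beyond the scatter), and an estimated value of 500 nM, between 50 nM and 5000 nM.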

Compound 3, half-maximal effective concentration: 19 nM
For compound 3 the middle estimate is 26-fold (1.42 log units) above the measured one; measured number outside the range, below it.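

Compound 3 shows that the low number of compound 1 does not depend on the 3-chlorophenyl ring alone: a different substituted ring on the same carbonyl carbon also gives a low number, with a modest gain of a 2.1-fold lower number from compound 1 to compound 3 (0.32 log units; beyond the scatter). Against the 2-methylphenyl ring, the same 4-(trifluoromethyl)phenyl ring gives a large change in this assay, namely an at least 520-fold lower number from compound 2 to compound 3 (2.72 log units; beyond the scatter). That step is only a floor, as compound 2 carries a limit of the assay and not a number: the limit of > 10000 nM in this assay, at which 1 of the 3 values shown sits.

The compounds shown leave open whether the high value of compound 2 comes from the methyl group itself or from where it sits on the ring. An unsubstituted phenyl ring, or a ring carrying a nitrile or a methoxy group, would help to separate these questions.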